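The compounds below may be only part of what the source reports. "The series", "measured", "known", "first", "only" and "open" are said of these compounds alone.

Measured compounds:
- compound 1, `CC1(C)N=C(N)N=C(N)N1c1ccc(OCc2ccc(S(=O)(=O)F)cc2)c(Cl)c1`, 7.58
- compound 2, `CC1(C)N=C(N)N=C(N)N1c1ccc(OCC(=O)Nc2cccc(S(=O)(=O)F)c2)c(Cl)c1`, 7.72

Both compounds were tested in an assay on isolated protein for inhibition of Dihydrofolate reductase (Mus musculus); on this read-out lower numbers stand for lower potency and higher numbers for higher potency (the scale is a negative logarithm). Among the two numbers, compound 1 has the lower one, but its nearest neighbour, compound 2, lies close enough that the two values cannot be told apart with confidence; they are best read as equally potent. The shared core of compound 1 and compound 2 is the same, and the two differ only in the linker that carries the fluorosulfonyl-bearing ring.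

Compound 3, `CC1(C)N=C(N)N=C(N)N1c1ccc(OCc2ccc(S(=O)(=O)F)cc2Cl)c(Cl)c1`, has not yet been measured. It differs from compound 1 in one place: chloro in place of hydrogen on an aromatic carbon. The new chlorine sits on an aromatic carbon of a six-membered aromatic ring of carbon only, ortho to a large group and meta to the fluorosulfonyl group. Going by the values given here, no measured pair here shows what a single added chloro does on this ring, so the expectation rests only on the two values at hand. The step from compound 1 to compound 3 is expected to be small, a number 0.12 log units higher from compound 1 to compound 3 (within the scatter), with no clear direction. Compound 3 is therefore estimated to give 7.7, likely between 7.2 and 8.2.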

Compound 3, logarithm of the reciprocal of the active concentration, log(1/C): 7.44
The estimate for compound 3 lay 0.26 log units above the measured number; measured number inside the range.
By their numbers in this assay, from the lowest: compounds 3, 1 and 2 (each within the scatter of the next).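

In this assay, chloro in place of hydrogen on this aromatic carbon, ortho to a large group and meta to a fluorosulfonyl group, gives a number 0.14 log units lower from compound 1 to compound 3 (within the scatter) and so leaves the two compounds indistinguishable in potency. Going by these compounds alone, this is the first comparison here between compounds that differ in one place only, and it shows that this carbon can carry a chlorine atom with no change in potency that stands out from the usual scatter of repeated measurements. Nothing available here bears on why the number stays where it does.

From the compounds shown here alone, whether a fluoro, a methyl or a methoxy group on this same carbon would read the same stays open, and so does the outcome for something much larger, such as a phenyl ring. Also open, going by these compounds, is whether a chloro on the fluorosulfonyl-bearing ring of compound 2, which carries that ring on a different linker, would leave the number as unchanged as it does in the step from hydrogen to chloro on compound 1.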